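Methylsulfanyl for Ethyl: an Untested Analogue of Compound 1

The source may report more compounds than this note shows. Statements on the series, on what has been measured and on what is new or still open speak of the compounds shown alone.

Compound 1, `CCCc1cc(N)c2cc(NC(=O)/C=C/c3ccc(CC)cc3)ccc2n1`: 160 nM
Compound 2, `CCCc1cc(N)c2cc(NC(=O)c3ccc(-c4ccc(Cl)cc4)cc3)ccc2n1`: 75 nM

Of the compounds shown here, two have been measured in a functional assay on HEK293 cells for activation of melanin-concentrating hormone receptor 1 (Homo sapiens), read by inositol phosphate accumulation; a lower number here means that less compound is needed, a higher number that more compound is needed for the effect. Compound 1 gives 160 nM, which is the higher of the two numbers, so more of it is needed. Compound 2 gives 75 nM, and the gap between these two values lies beyond the usual scatter; the two differ in several places at once, so nothing more can be drawn from that pair.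

Compound 3, `CCCc1cc(N)c2cc(NC(=O)/C=C/c3ccc(SC)cc3)ccc2n1`, is not yet measured. It differs from compound 1 in one place only: methylsulfanyl in place of ethyl on an aromatic carbon. Among the compounds with values here, no measured pair isolates this change, so there is no step to lean on. The group that leaves and the group that enters are of the same size, and the change sits far from the shared core. The expected step from compound 1 to compound 3 in this assay is therefore small, a 1.1-fold lower number from compound 1 to compound 3 (0.03 log units; within the scatter), not beyond the scatter in either direction. Compound 3 is estimated at 150 nM, with a likely range from 60 nM to 400 nM.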

Compound 3, half-maximal effective concentration: 71 nM
Estimate against measurement, compound 3: 2.1-fold (0.32 log units) above; the measured number falls inside the stated range.
By their numbers in this assay, from the lowest: compounds 3 and 2 (each within the scatter of the next); then compound 1.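

In this assay, this is the first step among the compounds shown that isolates one change: methylsulfanyl in place of ethyl on the aromatic carbon para to a large group gives a 2.3-fold lower number from compound 1 to compound 3 (0.35 log units; beyond the scatter) and lies beyond the scatter. The earlier pair differed in several places, so it could not show that this position responds to what sits on it. Here, even a swap between two groups with the same number of heavy atoms moves the number, though only modestly. Nothing measured here explains this step.

A methoxy group, with oxygen in place of sulfur, or a longer chain such as propyl at this place would show whether the sulfur itself matters. As far as these compounds go, whether the step carries over to other compounds also stays open, as this change appears only once here.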